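Shortening the isothiocyanate arm of compound 1

A few compounds are considered here, and "the series" means these few. Any claim that something is new, unique, unknown or untested is made for them only; others in the source may bear on it.

Measured so far:
compound 1, `CN(C)C(=O)c1cc2cnc(Nc3ccc(C(=O)NCCCCN=C=S)cc3)nc2n1C1CCCC1`: 30.2%
compound 2, `CN(C)C(=O)c1cc2cnc(Nc3ccc(C(=O)NCCCCN=C=S)cc3F)nc2n1C1CCCC1`: -7%

Among the measured compounds shown here, in a functional assay on A549 cells (Homo sapiens) for inhibition, read by CCK-8 assay, with a stated time of 72 h, tested at 1 uM (on this read-out lower numbers stand for a weaker effect and higher numbers for a stronger effect at the one concentration tested), compound 1 gives 30.2%, the higher of the two numbers so far; compound 2 gives -7%. For the measured compounds named here, the only step recorded, a number 37.2 percentage points lower from compound 1 to compound 2 (beyond the scatter), is large and downward for a small change on the shared core, which shows how sensitive this read-out can be to alterations on that ring.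

Compound 3, `CN(C)C(=O)c1cc2cnc(Nc3ccc(N=C=S)cc3)nc2n1C1CCCC1`, has not been measured. It differs from compound 1 by a group of 3 heavy atoms (1 carbon, 1 nitrogen, 1 sulfur; no ring) in place of a group of 10 heavy atoms (6 carbon, 2 nitrogen, 1 oxygen, 1 sulfur; no ring), on an aromatic carbon. Going by the values given here, no measured step covers this kind of change; the step from compound 1 to compound 2 concerns a different position and a different group, so it cannot be read across. The expectation therefore rests on compound 1 alone, with wide uncertainty. Compound 3 is estimated at 20%, within -10% to 50%, which means an expected step of a number 10.2 percentage points lower from compound 1 to compound 3 (beyond the scatter).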

Compound 3, a percentage reported as inhibition, at one concentration (the size of the read-out at that concentration, not a potency): 44.4%
Compound 3: the middle estimate sits 24.4 percentage points below what was measured; measured number inside the range.
By their numbers in this assay, from the lowest: compound 2; then compound 1; then compound 3.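

In this assay, placing the group of 3 heavy atoms on this aromatic carbon, para to a large group, in place of the group of 10 heavy atoms gives a number 14.2 percentage points higher from compound 1 to compound 3 (beyond the scatter). The long arm is therefore not needed to keep the effect at the one concentration tested, and the amide, with its 1 hydrogen-bond donor, can be lost from this position without any drop on this read-out. No available evidence accounts for the gain.

Going by these compounds, it remains open how an amine or a carboxylic acid on this aromatic carbon would compare with the isothiocyanate, and whether a chain of intermediate length would read like compound 1 or compound 3. Also open, on these data alone, is whether a fluoro on the ring of compound 3 would bring a drop like a number 37.2 percentage points lower from compound 1 to compound 2 (beyond the scatter).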